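The source may hold more compounds than are shown below. What is called first, only, known or untested is meant among the compounds shown, and "the series" means these compounds.

Compound 1 `CC(C)Oc1cccc(/C=N/n2c(-c3ccccc3)nc3ccccc3c2=O)c1` and compound 2 `CCOc1cccc(/C=N/n2c(-c3ccccc3)nc3ccccc3c2=O)c1` share one core and differ only in the group on the saturated chain carbon bound to an oxygen on an aromatic ring. For the measured compounds named here, in a functional assay on the whole organism (strain albino CF-1) with Mus musculus as the target, in the maximal electroshock model, with a stated time of 4 h (on this read-out higher numbers stand for an effect only at larger amounts of compound and lower numbers for an effect already at smaller amounts), compound 1 gives 300 mg/kg, while compound 2 gives 100 mg/kg, the lowest of the two numbers recorded; the single step, a 3.0-fold lower number from compound 1 to compound 2 (0.48 log units; beyond the scatter), lies beyond the scatter and is modest in size. Compound 3 `O=c1c2ccccc2nc(-c2ccccc2)n1/N=C/c1cccc(OCc2ccccc2)c1` has not yet been measured in this assay. It differs from compound 2 by phenyl in place of methyl on a saturated chain carbon bound to an oxygen on an aromatic ring. Going by the values given here, only the step from compound 1 to compound 2 bears on this change, and it concerns a smaller group on the same carbon, so it gives limited guidance. Compound 3 is therefore expected to land near compound 2, with a step of no change at the digits printed from compound 2 to compound 3 (within the scatter), within the scatter. The estimate for compound 3 in this assay is 100 mg/kg, with a range from 30 mg/kg to 300 mg/kg.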

Compound 3, minimum effective dose: 300 mg/kg
Beside the measured number, compound 3's estimate is 3.0-fold (0.48 log units) below it; the range from low to high includes it.
By their numbers in this assay, from the lowest: compound 2; then compounds 1 and 3 (each within the scatter of the next).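

Putting phenyl in place of methyl on a saturated chain carbon bound to an oxygen on an aromatic ring gives a 3.0-fold higher number from compound 2 to compound 3 (0.48 log units; beyond the scatter) in this assay and so shows that compound 2 stands apart from both other ethers, not only from the isopropyl one. Benzyl in place of isopropyl on an oxygen on an aromatic ring gives no change at the digits printed from compound 1 to compound 3 (within the scatter) and so shows that, in this set, a branched chain and one carrying an aromatic ring read alike. No supporting data are available to account for these results. The compounds shown leave open whether a methoxy group, a hydroxyl or an amine at this oxygen-bearing ring position would give a lower number than ethoxy. They also leave open whether an unbranched propoxy chain would read like ethoxy or like isopropoxy.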